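Replacing a Methoxy With Isopropylsulfanyl on the Carbamate Carbonyl

A few compounds are considered here, and "the series" means these few. Any claim that something is new, unique, unknown or untested is made for them only; others in the source may bear on it.

The measured compounds so far:
compound 1, `CC(C)(C)OC(=O)N1CCC(Oc2cccc3c2ccn3-c2ccc(S(C)(=O)=O)cc2)CC1`, 631 nM in a functional assay on CHO-K1 cells for agonist activity at Glucose-dependent insulinotropic receptor (Homo sapiens), read by a luciferase reporter, with a stated time of 5 h; a lower number here means that less compound is needed, a higher number that more compound is needed for the effect
compound 2, `CC(C)OC(=O)N1CCC(Oc2ncnc3c2CCN3c2ccc(S(C)(=O)=O)cc2)CC1`, 126 nM in this assay
compound 3, `COC(=O)N1CCC(Oc2ncnc3c2CCN3c2ccc(S(C)(=O)=O)cc2F)CC1`, 316 nM in this assay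

Compound 3 sits second highest of the three values in this assay. Its nearest neighbour is compound 1, whose number in this assay is within the usual scatter of that of compound 3, so no order can be read between these two. The lowest value belongs to compound 2, and the gap from compound 3 down to compound 2 lies beyond the scatter.

Compound 4, `CC(C)SC(=O)N1CCC(Oc2ncnc3c2CCN3c2ccc(S(C)(=O)=O)cc2F)CC1`, has not yet been measured in this assay. It differs from compound 3 in one place: isopropylsulfanyl in place of methoxy on a carbonyl carbon. The group that enters is larger than the one that leaves, and the carbon-oxygen link of the methoxy becomes a carbon-sulfur link, while the carbonyl and the ring nitrogen it sits on stay as they are.

For the measured compounds named here, no measured pair shows this exact change, so the size of the step rests on expectation alone. The estimate for compound 4 in this assay is a step of a 1.6-fold lower number from compound 3 to compound 4 (0.20 log units; within the scatter), which is expected to stay within the scatter or to be a modest lowering. The expected value for compound 4 is 200 nM, with a range from 60 nM to 650 nM.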

Compound 4, half-maximal effective concentration: 10 nM
The estimate for compound 4 lay 20-fold (1.30 log units) above the measured number; the whole stated range lies above it.
By their numbers in this assay, from the lowest: compound 4; then compound 2; then compounds 3 and 1 (each within the scatter of the next).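

On the carbonyl carbon whose other neighbour is the amide-type nitrogen in a ring, isopropylsulfanyl in place of methoxy gives a 32-fold lower number from compound 3 to compound 4 (1.50 log units; beyond the scatter) in this assay, so what sits at this place on the carbonyl can strongly change how much compound is needed for the effect. The earlier compounds shown here could not show this, as no two of them differed in one place, and this step is the only measure of a single change at this position. Nothing in the data shown gives a measured reason for the size of this step.

The change also alters two things at once, the atom attached to the carbonyl and the group beyond it, and the compounds shown do not separate them: isopropoxy or methylsulfanyl on the same carbonyl, with the rest of compound 4 unchanged, would each change only one. Also open, going by these compounds, is whether a longer chain on the sulfur, such as butylsulfanyl, or an amine on the carbonyl would keep the number as low as that of compound 4.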